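This account rests on a few compounds, and the source may have more. Where it says the series, first, only, none or still open, it means among the compounds named here.

Three compounds share one core, differing in the carbamate and in the aryl substituent. In a functional assay on cells for agonist activity at Glucose-dependent insulinotropic receptor (Homo sapiens), read by HTRF and cAMP accumulation, with a stated time of 30 min (a lower number here means that less compound is needed, a higher number that more compound is needed for the effect), compound 1 `CC(C)(C)OC(=O)N1CCC2(CC1)CC(CCCOc1ccc(S(C)(=O)=O)cc1)C2` gives 14 nM, compound 2 `CC(C)(C)COC(=O)N1CCC2(CC1)CC(CCCOc1ccc(S(C)(=O)=O)c(F)c1)C2` gives 31 nM, and compound 3 `CC(C)OC(=O)N1CCC2(CC1)CC(CCCOc1ccc(C(=O)NC3CC3)c(F)c1)C2` gives 8 nM. Compound 3 carries the lowest of the three numbers; compound 1 sits within the scatter of it, whereas compound 2 sits beyond it. Compound 4 `CC(C)OC(=O)N1CCC2(CC1)CC(CCCOc1ccc(C(=O)N3CC(O)C3)c(F)c1)C2` differs from compound 3 by 3-hydroxyazetidin-1-yl in place of cyclopropylamino on a carbonyl carbon. Among the measured compounds shown here, no measured pair shows this kind of change, so its effect is open. Compound 4 is expected to give 15 nM, between 5 nM and 45 nM. The step of a 1.9-fold higher number from compound 3 to compound 4 (0.27 log units; within the scatter) is expected to stay within the scatter, in the direction of slightly more compound needed.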

Compound 4, half-maximal effective concentration in the Glucose-dependent insulinotropic receptor assay: 40 nM
Compound 4: middle estimate off by 2.7-fold (0.43 log units), on the low side; low and high end bracket the measured number.
By their numbers in the Glucose-dependent insulinotropic receptor assay, from the lowest: compounds 3 and 1 (each within the scatter of the next); then compounds 2 and 4 (each within the scatter of the next).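

In the Glucose-dependent insulinotropic receptor assay, 3-hydroxyazetidin-1-yl in place of cyclopropylamino on a carbonyl carbon gives a 5.0-fold higher number from compound 3 to compound 4 (0.70 log units; beyond the scatter), so the group at this position does affect the number. In a physicochemical assay for solubility, read by HPLC, in phosphate buffer, with a stated time of 24 h, at pH 6.8 (a higher number here means a more soluble compound, a lower number a less soluble compound), compound 3 gives 0.21 ug/mL and compound 4 gives 1.89 ug/mL. The same change also shifts the result in the physicochemical assay, so a single change moves both read-outs, with more compound needed for the effect but a more soluble compound: the measured solubility of compound 3, 0.21 ug/mL, and of compound 4, 1.89 ug/mL, a 9.0-fold higher number (0.95 log units; beyond the scatter)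

The compounds shown do not tell whether the hydroxyl or the four-membered ring accounts for these shifts. An unsubstituted azetidin-1-yl or a morpholin-4-yl on the same carbonyl carbon would help separate the two.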